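The source may report more compounds than this note shows. Statements on the series, on what has been measured and on what is new or still open speak of the compounds shown alone.

Series notes, cell growth inhibition.

Of the compounds shown here, two carry a value so far. Compound 1 `Cc1nn(C)c(Oc2ccc(F)cc2)c1/C=N\OCc1c(Cl)c(-c2ccc(F)cc2)nn1C` gives 80% in a functional assay on SMMC-7721 cells (Homo sapiens) for inhibition, read by MTT assay, with a stated time of 72 h, tested at 25 uM; on this read-out lower numbers stand for less inhibition and higher numbers for more inhibition at the one concentration tested (going by the name of the read-out). Compound 2 `CCc1nn(C)c(CO/N=C/c2c(C)nn(C)c2Oc2cccc(Cl)c2)c1Cl` is the second. In this assay compound 2 gives < 80%, which is a limit of the assay and not a number, so where compound 2 stands on the scale is only bounded from one side. For the measured compounds named here, the one feature of the measured values worth noting is the limit of < 80% in this assay, at which 1 of the 2 values shown sits; the two compounds do not form a step that differs in one place, so no measured step is available.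

Compound 3 `CCc1nn(C)c(CO/N=C/c2c(C)nn(C)c2Oc2ccccc2C)c1Cl` is the next compound and has not yet been measured in this assay. Its relation to compound 2 is 2-methylphenyl in place of 3-chlorophenyl on an oxygen on an aromatic ring. With no measured step of this kind in the series, the expected step in this assay is a step that the limit leaves unreadable from compound 2 to compound 3, taken here as none beyond the scatter. On that basis compound 3 is estimated at 50% in this assay, with a range from 15% to 80%.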

Compound 3, a percentage reported as inhibition, at one concentration (the size of the read-out at that concentration, not a potency): < 80%
Compound 3 ended at the assay's limit; the forecaster's own chance of this, stated with the estimate: 55%; the middle value is on the limit's open side.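

No step can be read from compound 2 to compound 3 in this assay because both values are limits of the assay and not numbers: the limit of < 80% in this assay, at which 2 of the 3 values shown sit.

The compounds shown leave open how much inhibition compound 2 and compound 3 actually give, and whether 2-methylphenyl in place of 3-chlorophenyl changes it at all.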